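Swapping the methoxy for a second chloro on the core

This account rests on a few compounds, and the source may have more. Where it says the series, first, only, none or still open, it means among the compounds named here.

Measured so far, in a functional assay on ileum (strain Hartley) for agonist activity at 5-hydroxytryptamine receptor 3A (Cavia porcellus); on this read-out lower numbers stand for lower potency and higher numbers for higher potency (the scale is a negative logarithm):
- compound 1, `COc1cc(Cl)cc2nc(N3CCN(C)CC3)oc12`, gives 6.16
- compound 2, `COc1cc(C)cc2nc(N3CCN(C)CC3)oc12`, gives 6.13

Compound 1 holds the higher of the two numbers, but only just: the step of a number 0.03 log units lower from compound 1 to compound 2 (within the scatter), which exchanges one aromatic substituent for another, is within the scatter, so compounds 1 and 2 cannot be told apart on this read-out.

The next compound, compound 3, `CN1CCN(c2nc3cc(Cl)cc(Cl)c3o2)CC1`, changes compound 1 at a different place: chloro in place of methoxy on an aromatic carbon. For the measured compounds named here, the one measured step, from compound 1 to compound 2, concerns the chloro that stays in place in compound 3 and says nothing about the methoxy. Going by the values given here, no measured pair shows what removing a methoxy and putting a chloro there does. Among the compounds with values here, the only guidance is that a small substituent exchange on this core left the read-out unmoved, so for compound 3 the expectation is a step of no more than the scatter, with wide uncertainty, a step of a number 0.16 log units lower from compound 1 to compound 3 (within the scatter) in this assay. Compound 3 is therefore estimated at 6, between 5.4 and 6.6.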

Compound 3, negative logarithm of the half-maximal effective concentration: 6.51
Beside the measured number, compound 3's estimate is 0.51 log units below it; low and high end bracket the measured number.
By their numbers in this assay, from the lowest: compounds 2 and 1 (each within the scatter of the next); then compound 3.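

For the compounds shown here, this position on the core, an aromatic carbon ortho to a fused ring, is the first place where a single exchange moves the read-out beyond the scatter. In this assay, chloro in place of methoxy gives a number 0.35 log units higher from compound 1 to compound 3 (beyond the scatter), a modest step, whereas the earlier exchange of chloro for methyl at the other substituted carbon stayed within the scatter, so the read-out does respond to at least one substituent change on this core. Nothing measured alongside these numbers explains the step, and no information bearing on its cause is available.

With only methoxy and chloro shown at this carbon, it remains open whether the step comes from gaining chloro or from losing methoxy, and a plain hydrogen, a fluoro, a methyl or an ethoxy at the same carbon would help to separate those two readings. From the compounds shown here alone, it is also open whether the same exchange would give a similar step with methyl rather than chloro at the other substituted carbon.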